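Swapping the pyrimidinyl ring for a chlorine atom

A few compounds are considered here, and "the series" means these few. Any claim that something is new, unique, unknown or untested is made for them only; others in the source may bear on it.

Three compounds share the same core and differ only in the group attached to the five-membered ring. Compound 1 `N#Cc1cccc(-c2cnc(C(=O)CCCCCCc3ccccc3)o2)c1` gives 15 nM in an assay (Rattus norvegicus) for inhibition of Fatty-acid amide hydrolase 1 (Homo sapiens); a lower number here means a stronger inhibitor, a higher number a weaker inhibitor. Compound 2 `NC(=O)c1ccc(-c2cnc(C(=O)CCCCCCc3ccccc3)o2)cc1` gives 10 nM in this assay. Compound 3 `O=C(CCCCCCc1ccccc1)c1ncc(-c2ncccn2)o1` gives 5.3 nM in this assay, the lowest of the three numbers; its gap to compound 2 lies within the scatter, while a 2.8-fold lower number from compound 1 to compound 3 (0.45 log units; beyond the scatter) lies beyond it.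

Compound 4 `O=C(CCCCCCc1ccccc1)c1ncc(Cl)o1` carries the change (chloro in place of pyrimidin-2-yl on an aromatic carbon). Going by the values given here, the measured steps, a 1.5-fold lower number from compound 1 to compound 2 (0.18 log units; within the scatter) and a 1.9-fold lower number from compound 2 to compound 3 (0.28 log units; within the scatter) and a 2.8-fold lower number from compound 1 to compound 3 (0.45 log units; beyond the scatter), all exchange one six-membered ring for another; none removes the ring altogether, so no measured step bears directly on this change. Because a 2.8-fold lower number from compound 1 to compound 3 (0.45 log units; beyond the scatter) is the widest step among the three ring-bearing compounds and still keeps them within a narrow span, the ring itself seems to matter, and replacing it with a single chlorine is expected to give a higher number, with a 9.4-fold higher number from compound 3 to compound 4 (0.97 log units; beyond the scatter) as the estimated step. For compound 4 a value of 50 nM is expected, within 10 nM to 300 nM.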

Compound 4, inhibition constant: 5 nM
Compound 4: the middle estimate sits 10-fold (1.00 log units) above what was measured, and the stated range ends above it.
By their numbers in this assay, from the lowest: compounds 4, 3, 2 and 1 (each within the scatter of the next, the first and the last beyond it).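

At this position, on an aromatic carbon next to the ring oxygen, the whole pyrimidin-2-yl ring can give way to a single chlorine with no change that stands out from the scatter in this assay (a 1.1-fold lower number from compound 3 to compound 4 (0.03 log units; within the scatter)). The same holds against the larger ring of compound 2 (a 2.0-fold lower number from compound 2 to compound 4 (0.30 log units; within the scatter)), while only compound 1 stands apart from compound 4 (a 3.0-fold lower number from compound 1 to compound 4 (0.48 log units; beyond the scatter)). So across these four compounds, a six-membered aromatic ring at this place is not needed to keep the number low, and no measured evidence here accounts for this result.

As far as these compounds go, how an amine, a carboxylic acid or a methyl group at this place would read stays open. Also open, from the compounds shown here alone, is whether chloro would keep its number on a shorter chain.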